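Removing the aryl group from a non-toxic triazole series

The source may report more compounds than this note shows. Statements on the series, on what has been measured and on what is new or still open speak of the compounds shown alone.

Compound 1, `Cc1cc(=O)oc2cc(OCc3cn(-c4ccc(F)cc4F)nn3)ccc12`, gives > 100 ug/mL in an ADME assay on Huh-7 cells (Homo sapiens) for cytotoxicity, read by MTT assay, with a stated time of 72 h; on this read-out higher numbers stand for lower toxicity in this test and lower numbers for higher toxicity in this test; this value is a limit of the test, not a number.
Compound 2, `Cc1cc(=O)oc2cc(OCc3cn(-c4cccc(F)c4)nn3)ccc12`, gives > 100 ug/mL in this assay; this too is a limit.
Compound 3, `Cc1ccc(-n2cc(COc3ccc4c(C)cc(=O)oc4c3)nn2)c(Cl)c1`, gives > 100 ug/mL in this assay; again only a limit.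

Compound 3 thus stands at a limit, as do the other two: all three measured compounds sit at the limit of > 100 ug/mL in this assay, at which 3 of the 3 values shown sit, and none yields a number. The three steps among them cannot be sized: a step that the two limits leave unreadable from compound 1 to compound 2, a step that the two limits leave unreadable from compound 1 to compound 3 and a step that the two limits leave unreadable from compound 2 to compound 3.

Compound 4, `Cc1cc(=O)oc2cc(OCc3c[nH]nn3)ccc12`, is not yet measured. It differs from compound 3 by hydrogen in place of 2-chloro-4-methylphenyl on an aromatic nitrogen. Each of the three measured steps swaps one aryl group on that ring nitrogen for another, whereas in compound 4 the aryl group is gone altogether; each of those steps was unreadable, so they set neither a direction nor a size for this change. What they do show is that every aryl variant tried so far left the test without a number. The expected step is a step that the limit leaves unreadable from compound 3 to compound 4, nothing beyond the scatter. Compound 4 is therefore expected to give 120 ug/mL in this assay, within 50 ug/mL to 300 ug/mL, most likely again reported only as a limit.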

Compound 4, half-maximal cytotoxic concentration: > 100 ug/mL
Compound 4 was reported as a limit; the forecaster's own chance of this, stated with the estimate: 80%; the middle value is on the limit's open side.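

Compound 4 gives > 100 ug/mL in this assay and this too is only a limit, so no new step can be read from compound 1, compound 2 or compound 3 to compound 4, as all four compounds share one limit: the limit of > 100 ug/mL in this assay, at which 4 of the 4 values shown sit. The compounds shown leave open whether any of these changes on the ring nitrogen alters cytotoxicity, and by how much.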